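A few compounds are considered here, and "the series" means these few. Any claim that something is new, unique, unknown or untested is made for them only; others in the source may bear on it.

Measured in a functional assay for inhibition, with Rattus norvegicus as the target; on this read-out higher numbers stand for weaker inhibition and lower numbers for stronger inhibition:
- compound 1 `CCOC(=O)c1c(-c2ccccc2)c(OC(C)=O)c2ccccc2c1OC`: 5810 nM
- compound 2 `CCCCCc1c(C(=O)OCC)c(OC)c2ccccc2c1OC(C)=O`: 940 nM
- compound 3 `CCCCc1c(CC)c(OC(C)=O)c2ccccc2c1OC`: 1130 nM

At 1130 nM, compound 3 lies within the usual scatter of compound 2, while compound 1 shows a clearly higher number, and so weaker inhibition. The next compound, compound 4 `CCOC(=O)c1c(CC)c(OC(C)=O)c2ccccc2c1OC`, comes from compound 3 by placing ethoxycarbonyl where butyl stood: ethoxycarbonyl in place of butyl on an aromatic carbon.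

Among the measured compounds shown here, no measured step makes this exact swap. The closest evidence is the pair that already carries ethoxycarbonyl, where pentyl in place of phenyl gave a 6.2-fold lower number from compound 1 to compound 2 (0.79 log units; beyond the scatter). Compound 4 also carries ethoxycarbonyl, but has ethyl where compound 1 has phenyl and compound 2 has pentyl. With a chain rather than a ring there, it is expected to resemble compound 2, at 940 nM, more than compound 1. The estimated change is small, a 1.3-fold higher number from compound 3 to compound 4 (0.12 log units; within the scatter), and is expected to stay within the scatter. Compound 4 is expected at 1500 nM, with an estimated range from 500 nM to 4500 nM.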

Compound 4, half-maximal inhibitory concentration: 1160 nM
Compound 4: the middle estimate sits 1.3-fold (0.11 log units) above what was measured, and the stated range covers the measured number.
By their numbers in this assay, from the lowest: compounds 2, 3 and 4 (each within the scatter of the next); then compound 1.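

In this assay, ethoxycarbonyl in place of butyl gave a 1.0-fold higher number from compound 3 to compound 4 (0.01 log units; within the scatter) and so left the read-out unchanged at this position, even though the entering group has two hydrogen-bond acceptors and the leaving group has none. At the neighbouring ring position, where the ethyl group of compound 4 stands, the length of the chain made no clear difference, as the change from pentyl gave a 1.2-fold higher number from compound 2 to compound 4 (0.09 log units; within the scatter) with ethoxycarbonyl kept in place. Phenyl is what stands apart there, as ethyl in its place gave a 5.0-fold lower number from compound 1 to compound 4 (0.70 log units; beyond the scatter) and matched the gain already seen with pentyl.

On these data alone, it remains open whether a group of a different kind in place of ethoxycarbonyl, such as a carboxylic acid or an amine, would also leave the number unchanged. Nothing available explains why these swaps have the effects they do.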